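The source may report more compounds than this note shows. Statements on the series, on what has been measured and on what is new or still open speak of the compounds shown alone.

Working notes on the series, read in a functional assay on HeLa cells (Homo sapiens) for antiproliferative activity, read by MTT assay, with a stated time of 48 h; a higher number here means a weaker inhibitor, a lower number a stronger inhibitor. Among the measured compounds shown here, compound 1 `COc1cc(-c2nnc3c(OC4COC4)cc(-c4ccc5[nH]ccc5c4)cn23)cc(OC)c1OC` gives 2780 nM and compound 2 `COc1cc(-c2nnc3c(OC4CCC4)cc(-c4ccc5[nH]ccc5c4)cn23)cc(OC)c1OC` gives 142 nM, the lowest of the two numbers so far. For the measured compounds named here, the only measured step is a 20-fold lower number from compound 1 to compound 2 (1.29 log units; beyond the scatter), large and beyond the scatter, with cyclobutyl in place of oxetan-3-yl on an oxygen on an aromatic ring. Compound 3 `COc1cc(-c2nnc3c(OC4CN(C(C)(C)C)C4)cc(-c4ccc5[nH]ccc5c4)cn23)cc(OC)c1OC` follows from compound 2 with 1-(tert-butyl)azetidin-3-yl in place of cyclobutyl on an oxygen on an aromatic ring, that is, 1-(tert-butyl)azetidin-3-yl in place of cyclobutyl on the same oxygen. Compound 3 shares a hetero atom in the four-membered ring with compound 1 at 2780 nM, so a higher number is expected in this assay. Going by the values given here, no measurement yet covers a tert-butyl group, so the size stays uncertain. The expected step is a 6.3-fold higher number from compound 2 to compound 3 (0.80 log units; beyond the scatter), probably beyond the scatter. For compound 3 the estimate is 900 nM, with an expected range of 200 nM to 4000 nM.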

Compound 3, half-maximal inhibitory concentration: > 10000 nM
Compound 3 was reported as a limit; the forecaster's own chance of this, stated with the estimate: 10%; middle value at least 11-fold (1.04 log units) away from the limit.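

In this assay compound 3 stands only as a limit, not as a number: the limit of > 10000 nM in this assay, at which 1 of the 3 values shown sits. On this oxygen on an aromatic ring, 1-(tert-butyl)azetidin-3-yl in place of cyclobutyl gives an at least 70-fold higher number from compound 2 to compound 3 (1.84 log units; beyond the scatter), so the loss seen with oxetan-3-yl is not specific to that one ring. The same group in place of oxetan-3-yl gives an at least 3.5-fold higher number from compound 1 to compound 3 (0.55 log units; beyond the scatter), which makes compound 3 the weakest of the three, and among these compounds both four-membered rings with a hetero atom give higher numbers than cyclobutyl, with none going against this.

The ring nitrogen and the tert-butyl group enter together in one step, and the compounds shown do not separate them. On these data alone, whether an azetidin-3-yl with a methyl group on the nitrogen, or with a free ring amine, behaves like compound 3 stays open, as does the reading for a cyclopentyl ring on the same oxygen.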